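The compounds below may be only part of what the source reports. "The series", "measured", "known", "first", "only" and "open" are said of these compounds alone.

Compound 1 `O=C(Nc1ccc(F)cc1)N[C@H]1CC[C@H](Oc2ccc(F)cc2)CC1` gives 20000 nM in a functional assay on CRL2813 cells (Homo sapiens) for cytotoxicity, read by sulforhodamine B assay, with a stated time of 5 days (a higher number here means a weaker inhibitor, a lower number a stronger inhibitor), the higher of the two numbers in hand. Compound 2 `O=C(Nc1cccc(F)c1)N[C@H]1CC[C@H](Oc2ccc(F)cc2)CC1` gives 8300 nM in this assay, and a 2.4-fold lower number from compound 1 to compound 2 (0.38 log units; beyond the scatter). Compound 3 `COC(=O)c1ccc(NC(=O)N[C@H]2CC[C@H](Oc3ccc(F)cc3)CC2)cc1` carries methoxycarbonyl in place of fluoro on an aromatic carbon. Among the compounds with values here, the single measured step relocates the fluoro rather than replacing it, so it bears only loosely on this change, though it shows that a small alteration on that aryl group shifts the number modestly. A step of comparable size in either direction, or none beyond the scatter, is therefore expected. For compound 3 the estimate is 15000 nM, within 6000 nM to 40000 nM, which means a 1.3-fold lower number from compound 1 to compound 3 (0.12 log units; within the scatter).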

Compound 3, half-maximal inhibitory concentration: 11600 nM
Compound 3: the middle estimate sits 1.3-fold (0.11 log units) above what was measured; the measured number falls inside the stated range.
By their numbers in this assay, from the lowest: compounds 2, 3 and 1 (each within the scatter of the next, the first and the last beyond it).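

In this assay, methoxycarbonyl in place of fluoro on an aromatic carbon, para to a large group, gives a 1.7-fold lower number from compound 1 to compound 3 (0.24 log units; within the scatter) and so does not separate the two compounds. The earlier step only relocated the fluoro, whereas here a group of 4 heavy atoms with 2 hydrogen-bond acceptors replaces a single fluorine atom at this position, and the number stays within the scatter. No evidence at hand bears on this result.

From the compounds shown here alone, whether a carboxylic acid, an amine or a longer ester chain on this aromatic carbon would move the number beyond the scatter remains open. So does whether changes elsewhere on the shared core would do so.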